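Chain stereocentre inversion in an antiproliferative series

This account rests on a few compounds, and the source may have more. Where it says the series, first, only, none or still open, it means among the compounds named here.

Of the compounds shown here, two have been measured in a functional assay on MCF7 cells (Homo sapiens) for antiproliferative activity, read by MTT assay, with a stated time of 48 h, tested at 100 uM; on this read-out lower numbers stand for a stronger effect and higher numbers for a weaker effect at the one concentration tested. Compound 1 `C[C@@H](O)CCn1nc2c(Br)c(Br)c(Br)c(Br)c2n1` in this assay gives 0%. Compound 2 `OC(CCn1nc2c(Br)c(Br)c(Br)c(Br)c2n1)c1ccccc1` differs in the substituent on the chain, and in this assay compound 2 gives 0%. On these numbers compound 1 stands level with compound 2 at the digits shown; the nearest measured neighbour is compound 2, and the gap between them lies within the usual scatter, so no order between the two can be stated. Neither compound shows a measurable effect at the single concentration tested.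

Compound 3 `C[C@H](O)CCn1nc2c(Br)c(Br)c(Br)c(Br)c2n1` has not yet been measured. Relative to compound 1 the change is the two compounds have the same atoms and bonds and differ only in configuration as drawn: 1 of 1 stereo elements differ; a stereocentre at a saturated chain carbon is drawn R in compound 1 and S in compound 3. Within the data shown here, no step between two measured compounds involves a change of this kind, so the size of the step can rest only on what compound 1 and compound 2 show. With both measured compounds at the floor of the read-out, the step is expected to stay within the scatter, estimated as no change at the digits printed from compound 1 to compound 3 (within the scatter). Compound 3 is accordingly estimated at 0% in this assay, with a range from 0% to 10%.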

Compound 3, a percentage reported as activity, at one concentration (the size of the read-out at that concentration, not a potency): 6%
The estimate for compound 3 lay 6 percentage points below the measured number, and the stated range covers the measured number.
By their numbers in this assay, from the lowest: compounds 1, 2 and 3 (each within the scatter of the next).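

Inverting the stereocentre at the saturated chain carbon gives in this assay a number 6 percentage points higher from compound 1 to compound 3 (within the scatter). Among these compounds, this is the first step that can be read between two measured compounds, and it shows that, at this carbon, the configuration as drawn does not separate the pair beyond the scatter, with both numbers close to the floor of the read-out. The pair reads configuration alone, because no atom or bond enters or leaves: the fact that compounds 1 and 3 differ only in the configuration as drawn.

On these data alone, with all the numbers close to that floor at a single concentration, it remains open whether the configuration at this carbon would count in a compound of the series that gives a clear effect on the cells. Also open, as far as these compounds go, is what an amine or a carboxylic acid in place of the hydroxyl would do in this assay, and whether a longer chain carrying the same stereocentre would keep the two mirror-drawn forms as close together as compound 1 and compound 3 stand here.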